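Benzyl variation on a shared core: cytotoxicity working notes

This account rests on a few compounds, and the source may have more. Where it says the series, first, only, none or still open, it means among the compounds named here.

Measured in a functional assay on SGC-7901 cells (Homo sapiens) for cytotoxicity, read by MTT assay, with a stated time of 48 h; on this read-out lower numbers stand for stronger inhibition and higher numbers for weaker inhibition:
- compound 1, `Cc1cccc(Cn2cc(COc3ccc4c(=O)ccoc4c3)nn2)c1`: > 100000 nM
- compound 2, `O=c1ccoc2cc(OCc3cn(Cc4ccc(Cl)cc4Cl)nn3)ccc12`: > 100000 nM

Compound 2 has no number in this assay, only the limit > 100000 nM. Compound 1 likewise stands at a limit, > 100000 nM. Within the data shown here, the single measured step, a step that the two limits leave unreadable from compound 1 to compound 2, cannot be read in size or direction, because both of its ends sit at the limit of > 100000 nM in this assay, at which 2 of the 2 values shown sit. Among the measured compounds shown here, the series so far gives no measured value below that limit.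

Compound 3, `O=c1ccoc2cc(OCc3cn(Cc4cccc(F)c4)nn3)ccc12`, differs from compound 2 by 3-fluorophenyl in place of 2,4-dichlorophenyl on a saturated chain carbon bound to an aromatic nitrogen. This change touches the same place as the unreadable step from compound 1 to compound 2, and that step supplies no size, so nothing in the measured data points to a gain or a loss beyond the scatter. The expected step, a number no higher from compound 2 to compound 3 (the limit leaves the size open), is therefore essentially none, with the outcome most likely reported again as a limit. The estimate for compound 3 in this assay is 100000 nM, with a range from 30000 nM to 300000 nM.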

Compound 3, half-maximal inhibitory concentration: > 100000 nM
Compound 3: a limit, no number; the forecaster's own chance of this, stated with the estimate: 80%; the middle value lies on the limit itself.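

Compound 3, like compound 1 and compound 2, carries only a limit and no number, so no step among compound 1, compound 2 and compound 3 can be read in size or direction: the limit of > 100000 nM in this assay, at which 3 of the 3 values shown sit.

The compounds shown leave open whether any benzyl group on the shared core gives a measurable value in this assay.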